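This account rests on a few compounds, and the source may have more. Where it says the series, first, only, none or still open, it means among the compounds named here.

Measured in a functional assay on the whole organism with Rattus norvegicus as the target; on this read-out higher numbers stand for an effect only at larger amounts of compound and lower numbers for an effect already at smaller amounts:
- compound 1 `CCNc1cccc(NC(=O)C(=O)OCC)c1C#N`: 0.03 mg/kg
- compound 2 `CCCCNc1cccc(NC(=O)C(=O)OCC)c1C#N`: 0.3 mg/kg
- compound 3 `CCOC(=O)C(=O)Nc1cccc(C)c1C#N`: 5.3 mg/kg

Compound 3 has the highest number of the three, reached by a 180-fold higher number from compound 1 to compound 3 (2.25 log units; beyond the scatter) and by an 18-fold higher number from compound 2 to compound 3 (1.25 log units; beyond the scatter). Compound 4 `CCOC(=O)C(=O)Nc1cccc(F)c1C#N` differs from it in one place: fluoro in place of methyl on an aromatic carbon, ortho to a cyano group. Within the data shown here, no measured step makes this exchange. The two large steps above act on the same aromatic carbon, so changes there can move the number strongly in this assay. However, they replace ethylamino and butylamino, so they give no direction for fluoro. The estimated step is a 1.3-fold lower number from compound 3 to compound 4 (0.12 log units; within the scatter), and no shift beyond the scatter is expected. The estimate for compound 4 is 4 mg/kg, with an expected range of 1 mg/kg to 15 mg/kg.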

Compound 4, dose for half-maximal effect: 1.2 mg/kg
For compound 4 the middle estimate is 3.3-fold (0.52 log units) above the measured one; measured number inside the range.
By their numbers in this assay, from the lowest: compound 1; then compound 2; then compound 4; then compound 3.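

In this assay, a single-atom exchange on this aromatic carbon, ortho to a cyano group, shifts the number beyond the scatter: fluoro in place of methyl gives (a 4.4-fold lower number from compound 3 to compound 4 (0.65 log units; beyond the scatter)). Fluoro still stays behind both amino groups, against butylamino (a 4.0-fold higher number from compound 2 to compound 4 (0.60 log units; beyond the scatter)) and further against ethylamino (a 40-fold higher number from compound 1 to compound 4 (1.60 log units; beyond the scatter)). Nothing measured here explains the difference between fluoro and methyl.

Open, from the compounds shown here alone, is where chloro, methoxy or an unsubstituted amine would fall on this carbon. Also open, going by these compounds, is whether methylamino or propylamino would fit the gap between the ethylamino and butylamino compounds.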